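From compound 1 to compound 4: one ring group exchanged

This account rests on a few compounds, and the source may have more. Where it says the series, first, only, none or still open, it means among the compounds named here.

In an in vitro ADME assay on microsomes from liver (Simiiformes) (a lower number here means that the compound disappears faster, a higher number that the compound lasts longer), compound 1 `COCc1cc(CCCOc2c(C)cc(-c3noc(C(F)(F)F)n3)cc2C)on1` gives 1.58 h. Compound 3 `Cc1cc(CCCOc2c(C)cc(-c3noc(CC(F)(F)F)n3)cc2C)on1` gives 0.533 h, a lower number than that of compound 1 and a gap beyond the usual scatter, which makes compound 1 the higher of the two exact numbers available. Compound 2 `COCc1cc(CCCOc2c(C)cc(-c3noc(C4CC4)n3)cc2C)on1` reads > 2.5 h. That value is a limit of the assay and not an exact number.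

The next compound to consider is compound 4 `Cc1ccc(CCCOc2c(C)cc(-c3noc(C(F)(F)F)n3)cc2C)cn1`. It carries 6-methylpyridin-3-yl in place of 3-(methoxymethyl)-1,2-oxazol-5-yl on a saturated chain carbon, three bonds along the chain from an oxygen on an aromatic ring.

For the measured compounds named here, only one measured step is available: cyclopropyl in place of trifluoromethyl on an aromatic carbon, an at least 1.5-fold higher number from compound 1 to compound 2 (0.19 log units; that floor lies within the scatter). That floor lies within the scatter, and the step leaves the 3-(methoxymethyl)-1,2-oxazol-5-yl group untouched, so it says little about this exchange. No measurement tests the exchange directly, so the expectation starts from compound 1 at 1.58 h and allows a wide range. The expected step is a 1.3-fold lower number from compound 1 to compound 4 (0.12 log units; within the scatter), and it is not expected to exceed the scatter in this assay. For compound 4, the estimated half-life is 1.2 h, with an expected range of 0.4 h to 2.5 h.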

Compound 4, half-life: 1.97 h
Compound 4: the middle estimate sits 1.6-fold (0.22 log units) below what was measured; measured number inside the range.
By their numbers in this assay, from the lowest: compound 3; then compounds 1 and 4 (each within the scatter of the next). At a limit, above all of these: compound 2.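

For the compounds shown here, until now, the only readable step was the exchange on an aromatic carbon; this is the first step at a different place, on a saturated chain carbon, three bonds along the chain from an oxygen on an aromatic ring. In this assay, putting 6-methylpyridin-3-yl in place of 3-(methoxymethyl)-1,2-oxazol-5-yl gives a 1.2-fold higher number from compound 1 to compound 4 (0.10 log units; within the scatter), so a six-membered aromatic ring with one hetero atom and a five-membered aromatic ring with two hetero atoms cannot be told apart at this place by their half-lives. Nothing shown here explains why the two groups read alike.

Going by these compounds, it remains open whether this match would hold if 6-methylpyridin-3-yl were combined with cyclopropyl in place of trifluoromethyl on the aromatic carbon, since this single pair speaks only for a core that carries trifluoromethyl. Also open, on these data alone, is whether a quite different group at the same place, such as an amine or a carboxylic acid, or a longer chain leading to the ring, would move the half-life beyond the scatter.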